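Removing one methoxy from the trimethoxyphenyl arm of compound 2

The source may hold more compounds than are shown below. What is called first, only, known or untested is meant among the compounds shown, and "the series" means these compounds.

Compound 2 `COc1cc(/C=C2\CN(S(=O)(=O)c3ccc(NC(C)=O)cc3)C/C(=C\c3ccccc3F)C2=O)cc(OC)c1OC` in a functional assay on SMMC-7721 cells (Homo sapiens) for cytotoxicity, read by MTT assay, with a stated time of 24 h (on this read-out lower numbers stand for stronger inhibition and higher numbers for weaker inhibition), gives 3920 nM, the higher of the two numbers recorded, its nearest neighbour being compound 1 `CC(=O)Nc1ccc(S(=O)(=O)N2C/C(=C\c3ccc(C#N)cc3)C(=O)/C(=C/c3ccccc3F)C2)cc1`, which in this assay gives 3150 nM. Among the compounds with values here, the one step recorded, a 1.2-fold higher number from compound 1 to compound 2 (0.09 log units; within the scatter), exchanged the whole aryl group on that chain carbon and still moved the read-out only within the scatter. Compound 3 `COc1cc(/C=C2\CN(S(=O)(=O)c3ccc(NC(C)=O)cc3)C/C(=C\c3ccccc3F)C2=O)cc(OC)c1` carries a smaller change at the same arm: hydrogen in place of methoxy on an aromatic carbon. Since the full aryl exchange in a 1.2-fold higher number from compound 1 to compound 2 (0.09 log units; within the scatter) was without effect beyond the scatter, the loss of a single methoxy is expected to leave this assay essentially unchanged; the expected step is a 1.0-fold lower number from compound 2 to compound 3 (0.00 log units; within the scatter), with no direction claimed beyond the scatter. Compound 3 is therefore estimated at 3900 nM, within a range of 1500 nM to 10000 nM.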

Compound 3, half-maximal inhibitory concentration: 5210 nM
Beside the measured number, compound 3's estimate is 1.3-fold (0.13 log units) below it; the measured number falls inside the stated range.
By their numbers in this assay, from the lowest: compounds 1, 2 and 3 (each within the scatter of the next).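

In this assay, the methoxy para to a large group can be replaced by hydrogen, 3,4,5-trimethoxyphenyl becoming 3,5-dimethoxyphenyl, with a 1.3-fold higher number from compound 2 to compound 3 (0.12 log units; within the scatter). The earlier compounds shown here showed only the exchange of one whole aryl group for another on this chain carbon; this step shows that a single substituent on the ring can also go without a step beyond the scatter, and a 1.7-fold higher number from compound 1 to compound 3 (0.22 log units; within the scatter) places 3,5-dimethoxyphenyl level with 4-cyanophenyl in the same sense. Nothing available bears on the reason for this flat read-out.

Open, from the compounds shown here alone, is whether a group of another kind on this ring, such as an amine or a carboxylic acid, would stay within the scatter. Going by these compounds, a longer chain in place of the methoxy is equally open.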